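Oxolanyl to cyclopentyl on the amine of the shared core

This account rests on a few compounds, and the source may have more. Where it says the series, first, only, none or still open, it means among the compounds named here.

Measured in an assay on CHO cells for displacement of a labelled ligand from adenosine receptor A3 (Homo sapiens), read by scintillation counting, with a stated time of 3 h; on this read-out higher numbers stand for weaker inhibition and lower numbers for stronger inhibition:
compound 1 `CCn1c(-c2ccccc2)nc2c(NC3CCC3)ncnc21` gives 84 nM
compound 2 `CCCn1c(-c2ccccc2)nc2c(NC3CCCC3)ncnc21` gives 749 nM
compound 3 `CCn1c(-c2ccccc2)nc2c(NC3CCOC3)ncnc21` gives 1660 nM

Compound 3 stands highest of the three numbers; its nearest neighbour is compound 2 and its furthest is compound 1. The next compound, compound 4 `CCn1c(-c2ccccc2)nc2c(NC3CCCC3)ncnc21`, differs from compound 3 by cyclopentyl in place of oxolan-3-yl on a nitrogen on an aromatic ring. For the measured compounds named here, one measured step bears directly on this: a 20-fold higher number from compound 1 to compound 3 (1.30 log units; beyond the scatter), the step in which the oxolan-3-yl group entered. Compound 4 removes that group again and takes up cyclopentyl instead, so a move back in the opposite direction is expected. Compound 2 also carries cyclopentyl, though with a different chain on the core. Compound 4 is therefore expected to give a clearly lower number in this assay, a step of about an 11-fold lower number from compound 3 to compound 4 (1.04 log units; beyond the scatter). The estimate for compound 4 is 150 nM, within a range of 50 nM to 500 nM.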

Compound 4, inhibition constant: 354 nM
Compound 4: the middle estimate sits 2.4-fold (0.37 log units) below what was measured; low and high end bracket the measured number.
By their numbers in this assay, from the lowest: compound 1; then compound 4; then compound 2; then compound 3.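

In this assay, cyclopentyl in place of oxolan-3-yl gives a 4.7-fold lower number from compound 3 to compound 4 (0.67 log units; beyond the scatter), so the ring oxygen accounts for a real part of the high number at this nitrogen, though the ring size also counts: a 4.2-fold higher number from compound 1 to compound 4 (0.62 log units; beyond the scatter) separates the two carbon rings. With cyclopentyl held fixed, the chain on the core also matters, with a 2.1-fold lower number from compound 2 to compound 4 (0.33 log units; beyond the scatter) for hydrogen in place of methyl. Nothing measured here explains these steps.

As far as these compounds go, how a cyclohexyl group or a cyclopentyl ring bearing a hydroxyl group would read at this nitrogen stays open. So does whether the chain step holds with cyclobutyl.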